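Bornyl ester series: shortening the basic amine side group

The source may hold more compounds than are shown below. What is called first, only, known or untested is meant among the compounds shown, and "the series" means these compounds.

Within the data shown here, in an ADME assay on HEK-293T cells (Homo sapiens) for cytotoxicity, read by MTT assay, with a stated time of 48 h (on this read-out lower numbers stand for higher toxicity in this test and higher numbers for lower toxicity in this test), compound 2 `CN1CCN(CCC(=O)O[C@@H]2C[C@@H]3CC[C@@]2(C)C3(C)C)CC1` gives 282000 nM, the highest of the two numbers so far; compound 1 `CC1CCN(CC(=O)O[C@@H]2C[C@@H]3CC[C@@]2(C)C3(C)C)CC1` gives 71600 nM in this assay, and the gap between the two lies beyond the scatter. Among the measured compounds shown here, the two differ in more than one place, so no single step between them is drawn. Compound 3 `CN(C)CCC(=O)O[C@@H]1C[C@@H]2CC[C@@]1(C)C2(C)C` differs from compound 2 in one place: dimethylamino in place of 4-methylpiperazin-1-yl on a saturated chain carbon, two bonds along the chain from a carbonyl carbon. For the measured compounds named here, no measured pair shows the effect of this change. A modest step downward is expected, a 1.9-fold lower number from compound 2 to compound 3 (0.27 log units; within the scatter), close to the scatter. For compound 3 the expected value in this assay is 150000 nM, with a range from 50000 nM to 400000 nM.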

Compound 3, half-maximal cytotoxic concentration: 505000 nM
Compound 3: middle estimate off by 3.4-fold (0.53 log units), on the low side; measured number above the stated range.
By their numbers in this assay, from the lowest: compound 1; then compounds 2 and 3 (each within the scatter of the next).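

In this assay, dimethylamino in place of 4-methylpiperazin-1-yl on a saturated chain carbon, two bonds along the chain from a carbonyl carbon, gives a 1.8-fold higher number from compound 2 to compound 3 (0.25 log units; within the scatter), so at this place the ring can give way to the open amine without a reading outside the scatter. (Dimethylamino)methyl in place of 4-methylpiperidin-1-yl on a saturated chain carbon bound to a carbonyl carbon gives a 7.1-fold higher number from compound 1 to compound 3 (0.85 log units; beyond the scatter), a step that does lie beyond the scatter. Nothing on hand accounts for either step. Still open, on these data alone, is how a morpholin-4-yl group or a carboxylic acid at this place would read, and how a longer chain carrying dimethylamino would compare.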